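This account rests on a few compounds, and the source may have more. Where it says the series, first, only, none or still open, it means among the compounds named here.

Of the compounds shown here, three built on one shared core have been tested in a functional assay on U-937 cells (Homo sapiens) for cytotoxicity, read by MTT assay, with a stated time of 48 h (a lower number here means a stronger inhibitor, a higher number a weaker inhibitor), and all three sit at the weak end of what that test can resolve. Compound 1 `Fc1cccc(Nc2nc(-c3cccc(F)c3)nc3ccc(F)cc23)c1` gives 42300 nM in this assay. Compound 3 `Oc1ccccc1Nc1nc(-c2cccc(F)c2)nc2ccc(F)cc12` gives 46300 nM. Compound 2 `Fc1cccc(-c2nc(Nc3ccccc3Cl)c3cc(F)ccc3n2)c1` stands at the limit of > 50000 nM in this assay, at which 1 of the 3 values shown sits, so for compound 2 only a limit, > 50000 nM, is known and not a number. The group on the nitrogen of the core has been varied across these three, with little consequence: the step of an at least 1.1-fold higher number from compound 1 to compound 2 (0.07 log units; that floor lies within the scatter) and the step of an at least 1.0-fold lower number from compound 2 to compound 3 (0.03 log units; that floor lies within the scatter) both stay inside the scatter of repeated measurements, as does the step of a 1.1-fold higher number from compound 1 to compound 3 (0.04 log units; within the scatter).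

Compound 4 `Cc1ccc(Nc2nc(-c3cccc(F)c3)nc3ccc(F)cc23)cc1` differs from compound 2 by 4-methylphenyl in place of 2-chlorophenyl on a nitrogen on an aromatic ring. The group that leaves, 2-chlorophenyl, and the group that enters, 4-methylphenyl, are of the same size and carry no hydrogen-bond donors or acceptors. The two measured steps that touch compound 2 each moved the number by no more than the scatter, so the expected step of an at least 1.1-fold lower number from compound 2 to compound 4 (0.04 log units; that floor lies within the scatter) is likewise none beyond the scatter, in no particular direction. Compound 4 is therefore estimated at 45000 nM in this assay, within a range from 20000 nM to 100000 nM, with a real chance that only a limit is again reported.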

Compound 4, half-maximal inhibitory concentration: > 50000 nM
Compound 4: a limit, no number; the forecaster's own chance of this, stated with the estimate: 45%; middle value at least 1.1-fold (0.04 log units) from the limit.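

In this assay, compound 4 also gives only a limit and not a number, so a second group on this nitrogen, 4-methylphenyl, now stands with 2-chlorophenyl at the edge of what the test reports: the limit of > 50000 nM in this assay, at which 2 of the 4 values shown sit. The step between those two limits cannot be read, while the readable steps are only floors, an at least 1.1-fold higher number from compound 1 to compound 4 (0.07 log units; that floor lies within the scatter) and an at least 1.0-fold higher number from compound 3 to compound 4 (0.03 log units; that floor lies within the scatter), so the true gaps could be larger, but nothing shown sets compound 4 apart from compound 1 or compound 3. Among the compounds shown here, the new information is that a methyl group on the phenyl ring, a carbon-only replacement for the chlorine-bearing ring, still yields no compound with a step beyond the scatter, which extends the flat picture at this position to a fourth group.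

On these data alone, how far compound 2 and compound 4 lie past their limit stays unknown, so any real difference among the four compounds could be hidden there. As far as these compounds go, every group on this nitrogen is a substituted phenyl ring, so it remains open whether a phenyl ring bearing a carboxylic acid, or a chain ending in an amine, would bring a clearly stronger result in this assay.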